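Capping the pyrrolidine nitrogen in an antiproliferative series

This account rests on a few compounds, and the source may have more. Where it says the series, first, only, none or still open, it means among the compounds named here.

Measured so far:
compound 1 `CN1CCN(c2ccc(Nc3ncc4nc(Nc5ccccc5)n([C@H]5CCNC5)c4n3)cc2)CC1`: 530 nM
compound 2 `CN1CCN(c2ccc(Nc3ncc4nc(Nc5ccccc5)n([C@@H]5CCNC5)c4n3)cc2)CC1`: 65 nM
compound 3 `CN1CCN(c2ccc(Nc3ncc4nc(Nc5ccccc5)n([C@H]5CCN(S(C)(=O)=O)C5)c4n3)cc2)CC1`: 17 nM

In a functional assay on HCC827 cells (Homo sapiens) for antiproliferative activity, read by MTT assay, with a stated time of 72 h (a higher number here means a weaker inhibitor, a lower number a stronger inhibitor), compound 3 stands lowest of the three numbers. The nearest measured number lies one step away, a 3.8-fold lower number from compound 2 to compound 3 (0.58 log units; beyond the scatter); the furthest, a 31-fold lower number from compound 1 to compound 3 (1.49 log units; beyond the scatter). The remaining step, an 8.2-fold lower number from compound 1 to compound 2 (0.91 log units; beyond the scatter), concerns only configuration, because of the fact that compounds 1 and 2 differ only in the configuration as drawn, and does not bear on the present change.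

Compound 4 `CC(=O)N1CC[C@H](n2c(Nc3ccccc3)nc3cnc(Nc4ccc(N5CCN(C)CC5)cc4)nc32)C1` differs from compound 3 by acetyl in place of methylsulfonyl on an amine nitrogen in a ring. Both steps that bear on this ring nitrogen describe adding a cap where there was hydrogen; here one cap replaces another, so a smaller move is expected, estimated as a 1.5-fold higher number from compound 3 to compound 4 (0.17 log units; within the scatter), within the scatter. Compound 4 is expected to give 25 nM, with a range of 10 nM to 60 nM.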

Compound 4, half-maximal inhibitory concentration: 260 nM
For compound 4 the middle estimate is 10-fold (1.02 log units) below the measured one; measured number outside the range, above it.
By their numbers in this assay, from the lowest: compound 3; then compound 2; then compound 4; then compound 1.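

Swapping one cap for the other is no small move on this amine nitrogen in the ring: a 15-fold higher number from compound 3 to compound 4 (1.18 log units; beyond the scatter) is seen in this assay with acetyl in place of methylsulfonyl. Acetyl in place of hydrogen gives only a 2.0-fold lower number from compound 1 to compound 4 (0.31 log units; beyond the scatter) where methylsulfonyl gives a 31-fold lower number from compound 1 to compound 3 (1.49 log units; beyond the scatter) so the larger part of the gain goes with the methylsulfonyl cap. The step of a 4.0-fold higher number from compound 2 to compound 4 (0.60 log units; beyond the scatter) puts 1-acetylpyrrolidin-3-yl behind pyrrolidin-3-yl, a place that 1-(methylsulfonyl)pyrrolidin-3-yl does not share.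

Nothing measured here accounts for the gap between the two caps. Open, as far as these compounds go, is whether ethylsulfonyl, a longer chain on the sulfonyl, or a carbamate on this nitrogen would track methylsulfonyl or acetyl.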